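A few compounds are considered here, and "the series" means these few. Any claim that something is new, unique, unknown or untested is made for them only; others in the source may bear on it.

Four compounds share one core. In a functional assay on HCT-116 cells (Homo sapiens) for cytotoxicity (on this read-out lower numbers stand for an effect already at smaller amounts and higher numbers for an effect only at larger amounts of compound), compound 1 `COc1ccc(S(=O)(=O)Nc2ccc(C(=O)CSC(C)=O)cn2)cc1` gives 540 nM. In this assay compound 2 `CC(=O)SCC(=O)c1ccc(NS(=O)(=O)c2ccc(OCCCN3CCCC3)cc2)nc1` gives 820 nM, and the step of a 1.5-fold higher number from compound 1 to compound 2 (0.18 log units; within the scatter) stays within the scatter. For compound 3 `CC(=O)SCC(=O)c1ccc(NS(=O)(=O)c2ccc(OCCCc3ccccn3)cc2)nc1` the entry in this assay reads "not determined" (no result reported), so compound 3 stands without a value on the numbers shown. Compound 4 `CC(=O)SCC(=O)c1ccc(NS(=O)(=O)c2ccc(OC3CCN(C)CC3)cc2)nc1` differs from compound 3 by 1-methylpiperidin-4-yl in place of 3-(pyridin-2-yl)propyl on an oxygen on an aromatic ring. Going by the values given here, no measured step covers this exact change; the only recorded step, a 1.5-fold higher number from compound 1 to compound 2 (0.18 log units; within the scatter), adds a group at the same oxygen and left the number within the scatter. With compound 3 unmeasured, no direction can be read, and compound 4 is expected to land near compounds 1 and 2. Compound 4 is estimated at 800 nM, within a range from 300 nM to 2500 nM.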

Compound 4, half-maximal effective concentration: 180 nM
Compound 4: middle estimate off by 4.4-fold (0.65 log units), on the high side; the measured number lies below the stated range.
By their numbers in this assay, from the lowest: compound 4; then compounds 1 and 2 (each within the scatter of the next).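

Going by these compounds alone, at the oxygen on the aromatic ring, the earlier compounds showed no change beyond the scatter, but 1-methylpiperidin-4-yl brings one: in this assay there is a 4.6-fold lower number from compound 2 to compound 4 (0.66 log units; beyond the scatter) and a 3.0-fold lower number from compound 1 to compound 4 (0.48 log units; beyond the scatter). This position can therefore shift the number, and here 1-methylpiperidin-4-yl gives a lower one than either 3-(pyrrolidin-1-yl)propyl or methyl. Nothing shown explains this shift. Any step involving compound 3 cannot be read, as it has no value. Also open, from the compounds shown here alone, is whether a piperidin-4-yl group without the methyl, or a morpholine on a propyl chain, would give a similarly low number.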